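A methyl added to the anilide of compound 1

The source may report more compounds than this note shows. Statements on the series, on what has been measured and on what is new or still open speak of the compounds shown alone.

Three compounds have been measured in an assay on isolated protein for inhibition of Amine oxidase [flavin-containing] B (Homo sapiens), read by fluorescence and spectrophotometry; on this read-out lower numbers stand for stronger inhibition and higher numbers for weaker inhibition:

Compound 1, `O=C(CCCCc1cn(Cc2ccc3oc(-c4ccccc4)cc(=O)c3c2)nn1)Nc1ccccc1`, gives 15600 nM.
Compound 2, `O=C(NCc1cnnn1Cc1ccc2oc(-c3ccc(Cl)cc3)cc(=O)c2c1)c1ccccc1`, gives 32900 nM.
Compound 3, `O=C(CCc1cn(Cc2ccc3oc(-c4ccc(Cl)cc4)cc(=O)c3c2)nn1)Nc1ccc(Cl)cc1`, gives 32900 nM.

Among these three numbers compound 1 has the lowest, and both compound 2 and compound 3 lie beyond the usual scatter from it, so compound 1 is the strongest inhibitor of the three measured so far. No two of the measured compounds differ from one another in only one place, so nothing in this set shows directly how a single small change moves the number.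

Compound 4, `Cc1ccc(NC(=O)CCCCc2cn(Cc3ccc4oc(-c5ccccc5)cc(=O)c4c3)nn2)cc1`, differs from compound 1 in exactly one place: methyl in place of hydrogen on an aromatic carbon. For the measured compounds named here, a change of this size, one carbon added to the anilide ring, has no measured counterpart here to guide the expectation. The step of a 1.3-fold lower number from compound 1 to compound 4 (0.11 log units; within the scatter) is therefore expected to be small, most likely within the usual scatter, with at best a slight lean toward a lower number. Compound 4 is estimated at 12000 nM, with a range from 4000 nM to 40000 nM.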

Compound 4, half-maximal inhibitory concentration: 15600 nM
Compound 4: the middle estimate sits 1.3-fold (0.11 log units) below what was measured; measured number inside the range.
By their numbers in this assay, from the lowest: compounds 1 and 4 (each within the scatter of the next); then compounds 2 and 3 (each within the scatter of the next).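

In this assay, methyl in place of hydrogen on the aromatic carbon of the anilide ring, para to a large group, gives no change at the digits printed from compound 1 to compound 4 (within the scatter). For the compounds shown here, this is the first pair in the set that differs in only one place, so it is the first direct look at a single small change: at this position of the anilide ring, adding a methyl leaves the number where it was. No measurement at hand explains this outcome.

As far as these compounds go, the result covers only methyl at this one position on the core of compound 1, so it remains open whether a larger or very different group there, such as an amine, a carboxylic acid or a methoxy group, would also leave the number unchanged or would move it in either direction. From the compounds shown here alone, it is equally open whether the same methyl would behave this way elsewhere on the anilide ring, or on the phenyl ring at the far end of the core of compound 1.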